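Flipping a second stereocentre: how long will compound 3 last?

A few compounds are considered here, and "the series" means these few. Any claim that something is new, unique, unknown or untested is made for them only; others in the source may bear on it.

In an ADME assay (Mus musculus, strain C57BL/6) for metabolic stability, read by HPLC, with a stated time of 12 h (on this read-out higher numbers stand for a longer-lived compound and lower numbers for a shorter-lived compound), compound 1 (`O=C(N[C@H](CO)C(=O)O)[C@@H]1C[C@H](O)CN1`) shows > 12 h, which is a limit of the assay and not a number. For the measured compounds named here, compound 2 (`O=C(N[C@H](CO)C(=O)O)[C@@H]1C[C@@H](O)CN1`) gives 0.99 h, the only true number so far, and it stands on the short-lived side of compound 1. Compound 3 (`O=C(O)[C@H](CO)NC(=O)[C@@H]1C[C@@H](O)CN1`) departs from compound 2 in one way: the two compounds have the same atoms and bonds and differ only in configuration as drawn: 1 of 3 stereo elements differ; a stereocentre at a saturated chain carbon is drawn R in compound 2 and S in compound 3. A stereocentre is a carbon whose groups can take either of two mirror-image arrangements. Going by the values given here, the one measured step that bears on this is an at least 12-fold lower number from compound 1 to compound 2 (1.08 log units; beyond the scatter), which is large and beyond the scatter, and it comes with the fact that compounds 1 and 2 differ only in the configuration as drawn. That flip lay at a ring carbon rather than a chain carbon, so it suggests that a sizeable shift in this assay is possible but gives no direction. The expected step is small in the middle but uncertain, a 1.2-fold lower number from compound 2 to compound 3 (0.09 log units; within the scatter). For compound 3 the estimated value is 0.8 h, with an expected range from 0.15 h to 6 h.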

Compound 3, half-life: 0.88 h
Estimate against measurement, compound 3: 1.1-fold (0.04 log units) below; low and high end bracket the measured number.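

Inverting the chain stereocentre while the ring carbon stays drawn R gives a 1.1-fold lower number from compound 2 to compound 3 (0.05 log units; within the scatter) in this assay, so at this position the flip leaves the half-life within the usual scatter. Across two inverted stereocentres, the step is an at least 13-fold lower number from compound 1 to compound 3 (1.13 log units; beyond the scatter) and it remains large, and both short-lived compounds share the ring carbon drawn R. The value of compound 1, > 12 h, is a limit of the assay and not a number.

As far as these compounds go, it remains open whether the chain stereocentre would matter as little with the ring carbon drawn S. Also open is how the half-life would respond to a change of atoms instead of configuration, such as a methyl ester in place of the carboxylic acid.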